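The source may report more compounds than this note shows. Statements on the series, on what has been measured and on what is new or still open speak of the compounds shown alone.

In an ADME assay on the whole organism (blood, Mus musculus, strain C57BL/6) for pharmacokinetics, read by HPLC, with a stated time of 4 h, at a dose of 2 mg/kg by the intraperitoneal route (on this read-out lower numbers stand for lower exposure and higher numbers for higher exposure at the dose given), the measured compounds are:

Compound 1 `CN1CCN(S(=O)(=O)c2c(Cl)ccc(NC(=O)Nc3cccc(Cl)c3Cl)c2O)CC1` gives 303 ng.h/mL
Compound 2 `CN1CC2(CC(S(=O)(=O)c3c(Cl)ccc(NC(=O)Nc4cccc(F)c4Cl)c3O)C2)C1` gives 1050 ng.h/mL
Compound 3 `CN1CCC2(CC1)CC(S(=O)(=O)c1c(Cl)ccc(NC(=O)Nc3cccc(F)c3Cl)c1O)C2` gives 1390 ng.h/mL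

Compound 1 has the lowest number of the three, and the numbers of compound 2 and compound 3 both stand clear of it, beyond the usual scatter of repeat measurements. Compound 4 `C[C@@H]1CN(S(=O)(=O)c2c(Cl)ccc(NC(=O)Nc3cccc(Cl)c3Cl)c2O)C[C@H](C)O1` differs from compound 1 in one place only (2,6-dimethylmorpholin-4-yl in place of 4-methylpiperazin-1-yl on a sulfonyl sulfur). It carries 2,6-dimethylmorpholin-4-yl in place of 4-methylpiperazin-1-yl on a sulfonyl sulfur.

Among the compounds with values here, no measured step covers this exchange. The closest evidence is a different swap on a sulfonyl sulfur (a 1.3-fold higher number from compound 2 to compound 3 (0.12 log units; within the scatter)), and that step stayed within the scatter. Compound 2 and compound 3 also differ from compound 1 elsewhere in the molecule, so their gaps to compound 1 are not clean steps and can guide the estimate only loosely. Even so, compound 1 at 303 ng.h/mL lies under both other compounds, so a rise in this assay is expected rather than a fall, although a result within the scatter of compound 1 remains possible. The estimated step is modest (a 2.6-fold higher number from compound 1 to compound 4 (0.42 log units; beyond the scatter)). For compound 4 the expected value is 800 ng.h/mL (expected range 250 ng.h/mL to 3000 ng.h/mL).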

Compound 4, area under the concentration-time curve: 519 ng.h/mL
Beside the measured number, compound 4's estimate is 1.5-fold (0.19 log units) above it, and the stated range covers the measured number.
By their numbers in this assay, from the lowest: compounds 1 and 4 (each within the scatter of the next); then compounds 2 and 3 (each within the scatter of the next).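

In this assay, putting 2,6-dimethylmorpholin-4-yl in place of 4-methylpiperazin-1-yl on a sulfonyl sulfur gives a 1.7-fold higher number from compound 1 to compound 4 (0.23 log units; within the scatter), so on the core of compound 1 this position takes the exchange with no difference that can be told from repeat-measurement noise. Within the data shown here, this is the first one-place reading for these six-membered rings, as the only earlier step, a 1.3-fold higher number from compound 2 to compound 3 (0.12 log units; within the scatter), concerned other groups at the same kind of sulfur and also stayed within the scatter; together, the two steps show no exchange on this sulfur that moves the number clearly. No supporting measurement is available to explain why these two groups give such close numbers.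

Compound 2 and compound 3 differ from compound 1 in more than one place, so the compounds shown cannot tell how much of their distance from compound 1 belongs to the group on the sulfonyl sulfur. On these data alone, it also stays open whether an unsubstituted morpholin-4-yl group would give a number close to that of compound 4, which would separate the ring oxygen from the two methyl groups.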